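Acetyl-to-hydrogen change on a purine scaffold at the assay ceiling

This account rests on a few compounds, and the source may have more. Where it says the series, first, only, none or still open, it means among the compounds named here.

In a functional assay on HeLa cells (Homo sapiens) for inhibition (a higher number here means a weaker inhibitor, a lower number a stronger inhibitor), compound 1 `CC(O)n1cnc2c(N)nc(I)nc21` gives only a limit, > 500000 nM. Compound 2 `CC(=O)OC(C)n1cnc2c(N)nc(I)nc21` likewise reaches only a limit in this assay, > 500000 nM. Compound 3 `CC(=O)OC(C)n1cnc2c(S)nc(F)nc21` also shows only a limit in this assay, > 500000 nM. The change from compound 2 to compound 1 is hydrogen in place of acetyl on an oxygen on a saturated carbon, and the resulting step that the two limits leave unreadable from compound 2 to compound 1 cannot be read. The difference between the core of compound 2 and that of compound 3 is not broken down here. Compound 4 `CC(O)n1cnc2c(S)nc(F)nc21` carries the same change relative to compound 3, namely (hydrogen in place of acetyl on an oxygen on a saturated carbon). Since (the limit of > 500000 nM in this assay, at which 3 of the 3 values shown sit), the step of a number no higher from compound 3 to compound 4 (the limit leaves the size open) is expected to stay unreadable as well. Compound 4 is therefore estimated to give 500000 nM in this assay, most likely again as a limit.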

Compound 4, half-maximal inhibitory concentration: > 500000 nM
Compound 4: no number, only a limit (the forecaster's own chance of this, stated with the estimate: 85%); the middle value lies on the limit itself.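

The step between compound 3 and compound 4 in this assay cannot be read, as both values are limits: the limit of > 500000 nM in this assay, at which 4 of the 4 values shown sit. The compounds shown leave open how strongly each inhibits and whether acetoxy to hydroxy alters inhibition at all.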